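The source may report more compounds than this note shows. Statements on the series, on what has been measured and on what is new or still open speak of the compounds shown alone.

Measured so far in an ADME assay on microsomes from liver (Rattus norvegicus) for metabolic stability, read by LC-MS, using NADPH, with a stated time of 10 min, tested at 0.1 uM; on this read-out lower numbers stand for slow clearance and higher numbers for fast clearance:

compound 1 `O=C(NCCCCc1ccccc1)c1cccc(C2SCC(=O)N2c2cccc(-c3c[nH]nn3)c2)c1` gives 742 mL.min-1.g-1
compound 2 `O=C(NCCCCc1ccccc1)c1cccc(C2SCC(=O)N2c2ccccn2)c1` gives 1480 mL.min-1.g-1
compound 3 `O=C(NCCCCc1ccccc1)c1cccc(C2SCC(=O)N2c2cccc(F)c2)c1` gives 3240 mL.min-1.g-1

Compound 3 has the highest number of the three, so it is cleared fastest here. Compound 4 `O=C(NCCCCc1ccccc1)c1cccc(C2SCC(=O)N2c2ccccc2F)c1` has the same atoms as compound 3, joined differently: 2-fluorophenyl in place of 3-fluorophenyl on an amide-type nitrogen in a ring. In words, 2-fluorophenyl takes the place of 3-fluorophenyl on an amide-type nitrogen in a ring. Among the measured compounds shown here, no measured pair shows a change of this kind. The closest evidence comes from exchanges of one group for a quite different one. Replacing pyridin-2-yl with 3-fluorophenyl gave a 2.2-fold higher number from compound 2 to compound 3 (0.34 log units; beyond the scatter), and replacing 1H-1,2,3-triazol-4-yl with fluoro gave a 4.4-fold higher number from compound 1 to compound 3 (0.64 log units; beyond the scatter). Both steps were modest, and a 2.0-fold higher number from compound 1 to compound 2 (0.30 log units; within the scatter). The present change exchanges no atoms, so a smaller step than these is expected, probably none beyond the scatter in this assay. The expected result is a 1.1-fold lower number from compound 3 to compound 4 (0.03 log units; within the scatter). For compound 4 the estimated value is 3000 mL.min-1.g-1, with an expected range from 1400 mL.min-1.g-1 to 6000 mL.min-1.g-1.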

Compound 4, intrinsic clearance in microsomes: 2950 mL.min-1.g-1
The estimate for compound 4 lay 1.0-fold (0.01 log units) above the measured number; the range from low to high includes it.
By their numbers in this assay, from the lowest: compounds 1, 2, 4 and 3 (each within the scatter of the next, the first and the last beyond it).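

In this assay, 2-fluorophenyl in place of 3-fluorophenyl on the amide-type nitrogen in the ring leaves the two isomers indistinguishable (a 1.1-fold lower number from compound 3 to compound 4 (0.04 log units; within the scatter)), so this shift of the fluoro group has no effect that can be read here. Set against pyridin-2-yl, the 2-fluorophenyl group also stays within the scatter (a 2.0-fold higher number from compound 2 to compound 4 (0.30 log units; within the scatter)), whereas the group carrying the triazole remains clearly apart from it (a 4.0-fold higher number from compound 1 to compound 4 (0.60 log units; beyond the scatter)). No measurement shown explains these steps.

The compounds shown leave open how an unsubstituted phenyl or a 4-fluorophenyl group would compare on this same nitrogen. They also leave open whether a carboxylic acid or an amine in place of the fluoro group would bring the number closer to that of the triazole compound.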